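This account rests on a few compounds, and the source may have more. Where it says the series, first, only, none or still open, it means among the compounds named here.

Compound 1, `Cc1cc(NC(=O)c2ccc(Cl)cc2)ccc1NS(=O)(=O)C(F)(F)F`, gives 201000 nM in an ADME assay on HEK293 cells (Homo sapiens) for cytotoxicity, read by MTT assay, with a stated time of 48 h; a lower number here means a stronger inhibitor, a higher number a weaker inhibitor.
Compound 2, `Cc1cc(NC(=O)c2ccc(C#N)cc2)ccc1NS(=O)(=O)C(F)(F)F`, reaches only the limit of this assay, > 250000 nM.
Compound 3, `CS(=O)(=O)Nc1ccc(NC(=O)c2ccc(Cl)cc2)cc1F`, gives 216000 nM in this assay.

Compound 1 and compound 3 carry different cores; the difference between the two cores is not broken down here. From the compounds shown here alone, compound 2 differs from compound 1 by one change, (cyano in place of chloro on an aromatic carbon), and this assay records an at least 1.2-fold higher number from compound 1 to compound 2 (0.09 log units; that floor lies within the scatter), a step whose true size is unknown because of the limit of > 250000 nM in this assay, at which 1 of the 3 values shown sits. Compound 4, `CS(=O)(=O)Nc1ccc(NC(=O)c2ccc(C#N)cc2)cc1F`, is not yet measured; it differs from compound 3 by the same change, (cyano in place of chloro on an aromatic carbon), at a place described in the same words. The expected step is a 1.3-fold higher number from compound 3 to compound 4 (0.11 log units; within the scatter), resting on compound 3 at 216000 nM and on the step from compound 1 to compound 2. Compound 4 is therefore estimated at 280000 nM, between 180000 nM and 450000 nM.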

Compound 4, half-maximal inhibitory concentration: > 250000 nM
Compound 4 ended at the assay's limit (the forecaster's own chance of this, stated with the estimate: 55%); the middle value does not contradict the limit.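

In this assay, cyano in place of chloro on the second core gives an at least 1.1-fold higher number from compound 3 to compound 4 (0.06 log units; that floor lies within the scatter). Compound 2 and compound 4, the two cyano compounds, both end at a limit of the assay rather than at a number, so each step is only a floor, and neither floor shows a change larger than the scatter: the limit of > 250000 nM in this assay, at which 2 of the 4 values shown sit. The change can therefore be set side by side on the two cores, but nothing shows that it carries over with the same size: the same change on two cores in this assay, an at least 1.2-fold higher number (0.09 log units; that floor lies within the scatter) from compound 1 to compound 2 and an at least 1.1-fold higher number (0.06 log units; that floor lies within the scatter) from compound 3 to compound 4; the limit leaves it open whether they differ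

From the compounds shown here alone, the true size of the step on either core stays open. So does how this assay would read with another group at that place, such as an amine or a carboxylic acid.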